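Removing the tert-butoxycarbonyl cap in polyamine tetrabenzyl series

This account rests on a few compounds, and the source may have more. Where it says the series, first, only, none or still open, it means among the compounds named here.

Measured so far in an ADME assay on RAW264.7 cells (Mus musculus) for cytotoxicity, read by resazurin assay, with a stated time of 48 h; a lower number here means that less compound is tolerated, a higher number that more compound is tolerated:
compound 1 `CC(C)(C)OC(=O)NCCCCN(CCCN(Cc1ccccc1)Cc1ccccc1)CCCN(Cc1ccccc1)Cc1ccccc1` gives 12500 nM;
compound 2 `NCCCCN(CCCN(Cc1ccccc1)Cc1ccccc1)CCCN(Cc1ccccc1)Cc1ccccc1` gives 1200 nM;
compound 3 `CC(C)(C)OC(=O)NC1CCC(N(CCCN(Cc2ccc(F)cc2)Cc2ccc(F)cc2)CCCN(Cc2ccc(F)cc2)Cc2ccc(F)cc2)CC1` gives a limit, > 100000 nM.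

From compound 1 to compound 2 the change is hydrogen in place of tert-butoxycarbonyl on an amine nitrogen, and in this assay it makes a 10-fold lower number from compound 1 to compound 2 (1.02 log units; beyond the scatter). The unmeasured compound 4 `NC1CCC(N(CCCN(Cc2ccc(F)cc2)Cc2ccc(F)cc2)CCCN(Cc2ccc(F)cc2)Cc2ccc(F)cc2)CC1` stands to compound 3 as hydrogen in place of tert-butoxycarbonyl on an amine nitrogen; it is the same kind of change, but the amine nitrogen here carries a saturated ring carbon where in compound 1 it carries a saturated chain carbon. How the core of compound 3 differs from the core of compound 1 is not broken down here. The value of compound 3 is a limit only, so the starting point is uncertain. For compound 4 an expected step of an at least 5.0-fold lower number from compound 3 to compound 4 (0.69 log units; beyond the scatter) is estimated, resting on the measured step of a 10-fold lower number from compound 1 to compound 2 (1.02 log units; beyond the scatter) in this assay. The estimated value for compound 4 is 20000 nM.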

Compound 4, half-maximal cytotoxic concentration: 4500 nM
Compound 4: middle estimate off by 4.4-fold (0.65 log units), on the high side; measured number below the stated range.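

In this assay, hydrogen in place of tert-butoxycarbonyl on an amine nitrogen lowers the number on both cores, and where that nitrogen carries a saturated ring carbon the change gives an at least 22-fold lower number from compound 3 to compound 4 (1.34 log units; beyond the scatter). Compound 3 gives > 100000 nM, which is a limit and not a number. The direction of the change therefore carries from one core to the other, but its size on the second core stays unfixed, and no claim can be made that the size carries over or differs: the same change on two cores in this assay, a 10-fold lower number (1.02 log units; beyond the scatter) from compound 1 to compound 2 and an at least 22-fold lower number (1.34 log units; beyond the scatter) from compound 3 to compound 4; the limit leaves it open whether they differ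

Still open, on these data alone, is whether the direction holds with an acetyl cap in place of tert-butoxycarbonyl, or with a longer chain carrying the amine. The compounds shown do not separate the effect of the saturated ring carbon from the other differences between the two cores.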